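Methoxy count on the aryl ring and cytotoxicity at one concentration

A few compounds are considered here, and "the series" means these few. Any claim that something is new, unique, unknown or untested is made for them only; others in the source may bear on it.

Two aminophenyl enone pyrazoles carry the same core and differ only in the methoxy pattern on the pendant aryl ring. Compound 1 `COc1ccc(-c2cc(/C=C/C(=O)c3ccc(N)cc3)[nH]n2)cc1` carries a single methoxy group; in a functional assay on NCI-H226 cells (Homo sapiens) for cytotoxicity, read by sulforhodamine B assay, with a stated time of 48 h, tested at 1 uM (a lower number here means a stronger effect, a higher number a weaker effect of the compound at the concentration tested), compound 1 gives 86%. Compound 2 `COc1cc(-c2cc(/C=C/C(=O)c3ccc(N)cc3)[nH]n2)cc(OC)c1OC` carries three methoxy groups; in this assay compound 2 gives 88%. Compound 2 holds the higher of the two numbers, yet the two values lie within the scatter of each other, so no order between compound 1 and compound 2 can be read from them. Compound 3 `COc1ccc(-c2cc(/C=C/C(=O)c3ccc(N)cc3)[nH]n2)cc1OC` has not yet been run in this assay. Relative to compound 2 it shows (hydrogen in place of methoxy on an aromatic carbon). With compound 1 and compound 2 sitting so close, the expected step of a number 1 percentage points lower from compound 2 to compound 3 (within the scatter) is none beyond the scatter. Compound 3 is therefore estimated at 87%, with a range from 76% to 97%.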

Compound 3, a percentage reported as activity, at one concentration (the size of the read-out at that concentration, not a potency): 86%
Estimate against measurement, compound 3: 1 percentage points above; low and high end bracket the measured number.
By their numbers in this assay, from the lowest: compounds 1, 3 and 2 (each within the scatter of the next).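

In this assay, hydrogen in place of methoxy on an aromatic carbon, ortho to a methoxy group, gives a number 2 percentage points lower from compound 2 to compound 3 (within the scatter), and methoxy in place of hydrogen on an aromatic carbon gives no change at the digits printed from compound 1 to compound 3 (within the scatter). Among these compounds, these are the first single-place steps, and they link all three methoxy patterns: neither exchange, taken alone, separates its pair beyond the scatter at the concentration tested. No available evidence bears on the reason for these values.

As far as these compounds go, whether a hydroxyl, a fluorine or a longer chain such as ethoxy at this position would move the number beyond the scatter remains open. Also open, from the compounds shown here alone, is whether the methoxy exchanges stay within the scatter at other concentrations or in other cell lines.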